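Swapping a nitrile for a fluoropyridine in a cytotoxicity test

This account rests on a few compounds, and the source may have more. Where it says the series, first, only, none or still open, it means among the compounds named here.

Measured compounds:
- Compound 1 `N#CC1CC(=O)N(c2cnn3c2CN(C(=O)Nc2cc(F)c(F)c(F)c2)C(C2CC2)C3)C1`: > 200000 nM
- Compound 2 `CC1(C)CC(=O)N(c2cnn3c2CN(C(=O)Nc2cc(F)c(F)c(F)c2)C(C2CC2)C3)C1`: 115000 nM

In a toxicity assay on HepG2 2.2.15 cells (Homo sapiens) for cytotoxicity, read by CellTiter-Glo (on this read-out lower numbers stand for higher toxicity in this test and higher numbers for lower toxicity in this test), compound 1 gives > 200000 nM, which is a limit of the assay and not a number. Compound 1 therefore stands at the limit of > 200000 nM in this assay, at which 1 of the 2 values shown sits, and only a range is known for it. Compound 2 gives 115000 nM in this assay. Among the measured compounds shown here, the step between them, an at least 1.7-fold lower number from compound 1 to compound 2 (0.24 log units; that floor lies within the scatter), is the only measured step, and it comes from exchanging the cyano-bearing ring for a dimethyl-bearing one.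

Compound 3 `O=C1CC(c2ccc(F)cn2)CN1c1cnn2c1CN(C(=O)Nc1cc(F)c(F)c(F)c1)C(C1CC1)C2` is not yet measured. It differs from compound 1 in one place: 5-fluoropyridin-2-yl in place of cyano on a saturated ring carbon. For the measured compounds named here, the change is larger than the one from compound 1 to compound 2, yet the only comparison at hand touches the same position and stays within the scatter, so no step beyond the scatter is expected, with the open limit of compound 1 leaving room for a lower number. Compound 3 is expected to give about 100000 nM, between 30000 nM and 250000 nM, which means an expected step of an at least 2.0-fold lower number from compound 1 to compound 3 (0.30 log units; that floor lies within the scatter).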

Compound 3, half-maximal cytotoxic concentration: 38500 nM
Beside the measured number, compound 3's estimate is 2.6-fold (0.41 log units) above it; measured number inside the range.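

The saturated ring carbon two ring bonds from the ring nitrogen can move the read-out measurably in this assay: putting 5-fluoropyridin-2-yl in place of cyano gives an at least 5.1-fold lower number from compound 1 to compound 3 (0.71 log units; beyond the scatter). The earlier exchange at this ring gave only an at least 1.7-fold lower number from compound 1 to compound 2 (0.24 log units; that floor lies within the scatter), so it could not show that a change here moves the number beyond ordinary repeat variation, whereas the aromatic ring now shows this, with the lower number standing for higher toxicity in this test. The true size of the new step remains unknown, since the reading for compound 1 is a limit and not a number: the limit of > 200000 nM in this assay, at which 1 of the 3 values shown sits.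

On these data alone, it remains open which part of the entering group goes with the lower number, the ring itself, its nitrogen or its fluorine, and a plain phenyl group or an unfluorinated pyridin-2-yl group on this carbon would help separate these. As far as these compounds go, how a small group such as an aminomethyl or a carboxylic acid would read at this carbon also stays open, as does whether the same exchange would give a similar step on a core other than the one shared here.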